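Fluoro on the Benzyl Ring of Purine Anticonvulsants

The compounds below may be only part of what the source reports. "The series", "measured", "known", "first", "only" and "open" are said of these compounds alone.

Compound 1, `CNc1ncnc2c1ncn2Cc1cccc(F)c1`: 7 mg/kg
Compound 2, `CNc1ncnc2c1ncn2Cc1cccc(F)c1F`: 18 mg/kg
Compound 3, `CN(C)c1ncnc2c1ncn2Cc1ccccc1`: 6 mg/kg

All three compounds were tested in a functional assay on the whole organism with Rattus norvegicus as the target, in the maximal electroshock model; on this read-out lower numbers stand for an effect already at smaller amounts and higher numbers for an effect only at larger amounts of compound. Compound 1 and compound 2 share one core and differ by fluoro in place of hydrogen on an aromatic carbon, a change that brought a 2.6-fold higher number from compound 1 to compound 2 (0.41 log units; beyond the scatter). Compound 3 carries a different core; the difference between the core of compound 1 and the core of compound 3 is not broken down here. In this assay compound 3 gives the lowest of the three numbers, though its gap to compound 1 lies within the scatter, so the two cannot be ranked against each other.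

Compound 4, `CN(C)c1ncnc2c1ncn2Cc1ccccc1F`, has not yet been measured. It stands to compound 3 as compound 2 stands to compound 1: the difference is fluoro in place of hydrogen on an aromatic carbon. This is the same kind of change, not the same change, for the surroundings differ. In compound 2 the incoming fluoro sits ortho to a fluoro group and ortho to a large group, whereas in compound 4 it sits only ortho to a large group.

Going by the values given here, the step from compound 1 to compound 2 is the only guide available, and it went to a higher number, just beyond the scatter. On that basis compound 4 is expected to show a 2.0-fold higher number from compound 3 to compound 4 (0.30 log units; within the scatter) in this assay, a step of similar direction but with wide uncertainty, since the surroundings of the change differ and the cores are not the same. For compound 4 the estimate in this assay is therefore 12 mg/kg, expected to fall between 5 mg/kg and 30 mg/kg.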

Compound 4, dose for half-maximal effect: 8.8 mg/kg
The estimate for compound 4 lay 1.4-fold (0.13 log units) above the measured number; the measured number falls inside the stated range.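

In this assay, fluoro in place of hydrogen on an aromatic carbon, here ortho to a large group, brought a 1.5-fold higher number from compound 3 to compound 4 (0.17 log units; within the scatter), so on this core the effect of the change cannot be told apart from the ordinary spread of repeated measurements. Set beside the earlier step on the core of compound 1, the result gives no sign that the core alters what this change does: the same change on two cores in this assay, a 2.6-fold higher number (0.41 log units; beyond the scatter) from compound 1 to compound 2 and a 1.5-fold higher number (0.17 log units; within the scatter) from compound 3 to compound 4, 1.8-fold (0.24 log units) apart, within the scatter of two such steps This does not show that the change acts alike on both cores, since two pairs are too few to support a rule, only the step on the core of compound 1 lies beyond the scatter, and a modest difference between the cores could still be hidden in these numbers.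

The compounds shown leave open whether a chloro or methoxy group in place of the fluoro would behave in the same way on both cores. They also leave open whether the picture would hold with a longer chain, such as ethyl or propyl, in place of the methyl groups on the amine.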